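From Ethyl to Tert-Butyl: An Untested Step

A few compounds are considered here, and "the series" means these few. Any claim that something is new, unique, unknown or untested is made for them only; others in the source may bear on it.

Compound 1 `CCSC(=S)SCC(=O)c1ccc(Cl)c(Cl)c1` — 7940 nM
Compound 2 `CCSC(=S)SCC(=O)c1ccc(Cl)cc1` — 5010 nM
Compound 3 `CCSC(=S)SCC(=O)c1ccc(OC)cc1OC` — 12600 nM

Of the compounds shown here, three share a core and have been measured in a functional assay on HeLa cells (Homo sapiens) for antiproliferative activity, read by resazurin assay; a lower number here means a stronger inhibitor, a higher number a weaker inhibitor. Compound 1 gives 7940 nM, compound 2 gives 5010 nM and compound 3 gives 12600 nM. Compound 1 gives the middle of these three numbers, but its gap to compound 2 is within the scatter, and so is its gap to compound 3, so the three are not separated by this assay.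

For the measured compounds named here, the only step between two measured compounds is a 1.6-fold lower number from compound 1 to compound 2 (0.20 log units; within the scatter), a change on the aromatic ring that did nothing beyond the scatter.

Compound 4 `CC(C)(C)SC(=S)SCC(=O)c1ccc(Cl)c(Cl)c1` has not yet been measured. It differs from compound 1 in one place: tert-butyl in place of ethyl on a sulfur. Going by the values given here, no measured step touches this sulfur, so the one recorded step does not bear on it directly; it only shows that a small change elsewhere on the core left the number where it was. With nothing to suggest a shift, no step beyond the scatter is expected from compound 1 to compound 4 in this assay, with the range kept wide for the lack of a precedent.

The expected step is a 1.1-fold lower number from compound 1 to compound 4 (0.02 log units; within the scatter). Compound 4 is therefore estimated at 7500 nM, within 3000 nM to 20000 nM.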

Compound 4, half-maximal inhibitory concentration: 10000 nM
Estimate against measurement, compound 4: 1.3-fold (0.12 log units) below; low and high end bracket the measured number.
By their numbers in this assay, from the lowest: compounds 2, 1, 4 and 3 (each within the scatter of the next, the first and the last beyond it).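

In this assay, for the compounds shown here, the step of a 1.3-fold higher number from compound 1 to compound 4 (0.10 log units; within the scatter) is the first reading at the sulfur whose other neighbour is the thiocarbonyl carbon, since the earlier step changed only a substituent on the aromatic ring. It shows that ethylsulfanyl to (tert-butyl)sulfanyl, which puts tert-butyl with 4 heavy atoms where ethyl with 2 heavy atoms stood, does not move the number beyond the scatter, so this one change at the sulfur leaves compound 4 unseparated from compound 1. No measurement shown here offers an explanation for this outcome.

Whether a longer chain, a benzyl group or a chain ending in an amine or a carboxylic acid on this sulfur would give a step beyond the scatter remains open, since ethyl and tert-butyl are the only two groups shown there. From the compounds shown here alone, the change is also read only on the core of compound 1, so it remains open whether tert-butyl in place of ethyl would give a similar result with the aromatic ring of compound 2 or compound 3.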